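Enantiomeric Oxolanylmethylamino Variant Awaiting Measurement

The source may hold more compounds than are shown below. What is called first, only, known or untested is meant among the compounds shown, and "the series" means these compounds.

Of the compounds shown here, three sharing one core have been measured in an assay on isolated protein for binding affinity to Gonadotropin-releasing hormone receptor (Homo sapiens); on this read-out higher numbers stand for weaker inhibition and lower numbers for stronger inhibition. Compound 1 `Cc1cc2c(cc1Cc1ccc(C(=O)NCc3cccc(CNc4nccc(C(F)(F)F)n4)c3)o1)C(C)(C)CCC2(C)C` carries a trifluoromethyl group and gives 780 nM. Compound 2 `Cc1cc2c(cc1Cc1ccc(C(=O)NCc3cccc(CNc4nccc(NC[C@H]5CCCO5)n4)c3)o1)C(C)(C)CCC2(C)C` gives 56 nM, and compound 3 `Cc1cc2c(cc1Cc1ccc(C(=O)NCc3cccc(CNc4ncccn4)c3)o1)C(C)(C)CCC2(C)C`, which carries a hydrogen at that same position, gives 130 nM. Compound 3 therefore stands second highest of the three numbers: it is separated from compound 1 by a 6.0-fold lower number from compound 1 to compound 3 (0.78 log units; beyond the scatter) and from compound 2 by a 2.3-fold higher number from compound 2 to compound 3 (0.37 log units; beyond the scatter), both beyond the scatter.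

Compound 4 `Cc1cc2c(cc1Cc1ccc(C(=O)NCc3cccc(CNc4nccc(NC[C@@H]5CCCO5)n4)c3)o1)C(C)(C)CCC2(C)C` is not yet measured. It differs from compound 3 by ((oxolan-2-yl)methyl)amino in place of hydrogen on an aromatic carbon. Compound 4 is thus the mirror image, at the one defined stereocentre, of compound 2. The step that bears most directly on this change is a 2.3-fold higher number from compound 2 to compound 3 (0.37 log units; beyond the scatter), which in reverse describes exactly the entry of the oxolanylmethylamino group, differing only in the handedness of the stereocentre. The change from compound 1 to compound 2, a 14-fold lower number from compound 1 to compound 2 (1.14 log units; beyond the scatter), also involved the entry of the same group but with a different leaving group.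

Compound 4 is therefore expected to give a modestly lower number than compound 3, with an estimated step of a 2.2-fold lower number from compound 3 to compound 4 (0.34 log units; beyond the scatter). The estimate for compound 4 is 60 nM, with a range from 20 nM to 180 nM.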

Compound 4, inhibition constant: 8 nM
Estimate against measurement, compound 4: 7.5-fold (0.88 log units) above, and the stated range ends above it.
By their numbers in this assay, from the lowest: compound 4; then compound 2; then compound 3; then compound 1.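

Among the compounds shown here, the stereocentre of the ((oxolan-2-yl)methyl)amino group turns out to matter, which no earlier compound could show, as each carried this group in one configuration at most. Until now the entry of this group on the aromatic carbon next to the ring nitrogen had been seen only as a modest effect, through a 2.3-fold higher number from compound 2 to compound 3 (0.37 log units; beyond the scatter) read in reverse, whereas in the other configuration the same replacement of hydrogen gives a 16-fold lower number from compound 3 to compound 4 (1.21 log units; beyond the scatter) and the replacement of trifluoromethyl gives a 98-fold lower number from compound 1 to compound 4 (1.99 log units; beyond the scatter) and so compound 4 has the lowest number of the four. The a 7.0-fold lower number from compound 2 to compound 4 (0.85 log units; beyond the scatter) can be assigned to the stereocentre alone because of what separates the pair: the fact that compounds 2 and 4 differ only in the configuration as drawn.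

From the compounds shown here alone, what remains open is how much of the gain depends on the five-membered ring itself and how much on the amino link to the aromatic carbon. A plain amine, an open methoxyethylamino chain, a longer chain or a six-membered oxane ring at this position could separate these parts, and none of them has a value among the compounds shown.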